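Swapping the pendant aryl ring in a weakly cytotoxic series

The source may hold more compounds than are shown below. What is called first, only, known or untested is meant among the compounds shown, and "the series" means these compounds.

Measured compounds:
Compound 1, `O=c1oc2ccccc2c2nc3c(ccc4cc[nH]c43)c(-c3ccc(O)cc3)c12`: 70700 nM
Compound 2, `O=c1oc2ccccc2c2nc3c(ccc4cc[nH]c43)c(-c3ccc(C(F)(F)F)cc3)c12`: 70700 nM
Compound 3, `O=c1oc2ccccc2c2nc3c(ccc4cc[nH]c43)c(-c3ccc(F)cc3)c12`: 70700 nM

All three compounds share one fused core and differ only in the group on the pendant benzene ring. In a functional assay on B16-F10 cells (Mus musculus) for cytotoxicity (a higher number here means a weaker inhibitor, a lower number a stronger inhibitor), compound 1 gives 70700 nM, compound 2 gives 70700 nM and compound 3 gives 70700 nM. Compound 2 therefore stands level with compounds 1 and 3; the three values cannot be told apart.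

The steps recorded so far, no change at the digits printed from compound 1 to compound 2 (within the scatter), no change at the digits printed from compound 1 to compound 3 (within the scatter) and no change at the digits printed from compound 2 to compound 3 (within the scatter), all exchange the substituent on that benzene ring and all stay within the scatter. None of them replaces the ring itself.

Compound 4, `O=c1oc2ccccc2c2nc3c(ccc4cc[nH]c43)c(-c3ccccn3)c12`, does exactly that: pyridin-2-yl in place of 4-(trifluoromethyl)phenyl on an aromatic carbon. Among the measured compounds shown here, no measured step bears directly on this change, so the nearest guide is the flat behaviour of compounds 1, 2 and 3 in this assay. The expectation for compound 4 is a step of no change at the digits printed from compound 2 to compound 4 (within the scatter), that is, no movement beyond the scatter, with the range widened to allow for an untested kind of change. Compound 4 is expected to give 70700 nM, between 20000 nM and 150000 nM.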

Compound 4, half-maximal inhibitory concentration: 70700 nM
For compound 4 middle estimate and measured number coincide at the digits printed; measured number inside the range.
By their numbers in this assay, from the lowest: compounds 1, 2, 3 and 4 (each within the scatter of the next).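

In this assay, putting pyridin-2-yl on this aromatic carbon gives no change at the digits printed from compound 2 to compound 4 (within the scatter), and the same holds for the other two comparisons: no change at the digits printed from compound 3 to compound 4 (within the scatter) and no change at the digits printed from compound 1 to compound 4 (within the scatter). The earlier compounds shown here showed only that the substituent on the pendant benzene ring could be exchanged without a visible shift, whereas this result extends that to the ring itself, with a ring nitrogen entering and the group shrinking from 10 heavy atoms to 6. No measurement here explains why the value holds steady through these changes.

As far as these compounds go, all four compounds keep a six-membered aromatic ring at this position, so it remains open whether pyridin-3-yl, a non-aromatic group such as a morpholine ring, an amine, a carboxylic acid or a longer alkyl chain would move the number. The shared core is also the same throughout, which leaves open whether a chlorine or a methyl group placed on the core would shift the value where changes to the pendant ring have not.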